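A few compounds are considered here, and "the series" means these few. Any claim that something is new, unique, unknown or untested is made for them only; others in the source may bear on it.

Measured compounds in a toxicity assay on HT-29 cells (Homo sapiens) for cytotoxicity; on this read-out higher numbers stand for lower toxicity in this test and lower numbers for higher toxicity in this test:
Compound 1, `CN1C(=S)[C@@H](NC(=O)c2nc(Cc3ccccc3)n(CCCCC#N)n2)COc2ccccc21`. In this assay compound 1 gives > 100000 nM, which is a limit of the assay and not a number.
Compound 2, `CN1C(=S)[C@@H](NC(=O)c2nc(Cc3ccccc3)n(C3CCOCC3)n2)COc2ccccc21`. In this assay compound 2 gives > 100000 nM, again a limit of the assay rather than a number.

Compound 2 therefore stands at the limit, where both values on hand sit (the limit of > 100000 nM in this assay, at which 2 of the 2 values shown sit). Among the compounds with values here, the one measured step, a step that the two limits leave unreadable from compound 1 to compound 2, has no readable size; both of its ends are limits. No toxicity in this test has been registered for either compound.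

Compound 3 is `CN1C(=S)[C@@H](NC(=O)c2nc(Cc3ccccc3)n(-c3ncccn3)n2)COc2ccccc21`. It differs from compound 2 only in pyrimidin-2-yl in place of oxan-4-yl on an aromatic nitrogen. Within the data shown here, the only step that bears on it is a step that the two limits leave unreadable from compound 1 to compound 2, unreadable in size, showing that exchanging the group on this aromatic nitrogen, from 4-cyanobutyl to oxan-4-yl, did not bring toxicity in this test into the measurable range. For compound 3 the step that the limit leaves unreadable from compound 2 to compound 3 is expected to be none beyond the scatter, with this assay most likely again reporting only a limit. The estimate for compound 3 in this assay is 150000 nM, with a range from 50000 nM to 500000 nM.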

Compound 3, half-maximal cytotoxic concentration: > 100000 nM
Compound 3: only a limit was reported; the forecaster's own chance of this, stated with the estimate: 80%; the middle value lies beyond the limit too.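

In this assay, within the data shown here, no step among compound 1, compound 2 and compound 3 can be read, as all three values are limits of the assay and not numbers: the limit of > 100000 nM in this assay, at which 3 of the 3 values shown sit.
The compounds shown leave open how far apart these three lie and whether any group on this aromatic nitrogen brings toxicity in this test into the measurable range.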